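Closing the amine of compound 2 into a pyrrolidine ring

A few compounds are considered here, and "the series" means these few. Any claim that something is new, unique, unknown or untested is made for them only; others in the source may bear on it.

Compound 2 `CN(c1ccc2cc(NC(=O)CCc3ccc(C(F)(F)F)cc3)ccc2n1)C1CCCC1` gives 350 nM in a functional assay on HEK293 cells for activation of melanin-concentrating hormone receptor 1 (Rattus norvegicus), read by inositol phosphate accumulation (a lower number here means that less compound is needed, a higher number that more compound is needed for the effect), the lowest of the two numbers measured; compound 1 `CN(c1ccc2cc(NC(=O)CCc3ccc(C(F)(F)F)cc3)ccc2n1)C1CCCCC1` gives 1200 nM, and a 3.4-fold lower number from compound 1 to compound 2 (0.54 log units; beyond the scatter). Compound 3 `CC1CCN(c2ccc3cc(NC(=O)CCc4ccc(C(F)(F)F)cc4)ccc3n2)C1` carries 3-methylpyrrolidin-1-yl in place of cyclopentyl(methyl)amino on an aromatic carbon. For the measured compounds named here, the only measured step, from compound 1 to compound 2, swaps one ring for another while the nitrogen keeps its methyl, whereas compound 3 folds that methyl into the ring, so the step bears on the new change only loosely. Compound 3 is expected at 300 nM in this assay, with a range from 100 nM to 1000 nM. That would mean a 1.2-fold lower number from compound 2 to compound 3 (0.07 log units; within the scatter), a step expected to stay within the scatter.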

Compound 3, half-maximal effective concentration: 400 nM
Beside the measured number, compound 3's estimate is 1.3-fold (0.12 log units) below it; the range from low to high includes it.
By their numbers in this assay, from the lowest: compounds 2 and 3 (each within the scatter of the next); then compound 1.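

In this assay, 3-methylpyrrolidin-1-yl in place of cyclopentyl(methyl)amino gives a 1.1-fold higher number from compound 2 to compound 3 (0.06 log units; within the scatter), so on this aromatic carbon a ring that contains the attached nitrogen is tolerated as well as a ring carried on a methylated nitrogen. Set against cyclohexyl(methyl)amino, the same group gives a 3.0-fold lower number from compound 1 to compound 3 (0.48 log units; beyond the scatter). Nothing available explains these numbers. The compounds shown leave open what the methyl on the pyrrolidine ring contributes, and how an unsubstituted pyrrolidine, a piperidine or a morpholine would compare at this place.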